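This account rests on a few compounds, and the source may have more. Where it says the series, first, only, none or still open, it means among the compounds named here.

Compound 1 `CCCCC[Se]c1nc([Se]CCCCC)c2ccccc2n1` gives in an ADME assay on BEAS-2B cells (Homo sapiens) for cytotoxicity, read by MTT assay, with a stated time of 72 h (a higher number here means a weaker inhibitor of growth, a lower number a stronger inhibitor of growth), only a limit, > 100000 nM.
Compound 2 `CCCCC[Se]c1nc(NCc2ccccc2)c2ccccc2n1` also gives in this assay only a limit, > 100000 nM.

Among the compounds with values here, compound 2 thus stands at the limit of this assay rather than at a number, and the one measured step that leads to it, a step that the two limits leave unreadable from compound 1 to compound 2, cannot be read in size or direction. Within the data shown here, the only evidence on the series is the limit of > 100000 nM in this assay, at which 2 of the 2 values shown sit, which says that neither measured compound reaches a readable growth inhibition.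

Compound 3 `CCCCC[Se]c1nc(N)c2ccccc2n1` has not been measured. It differs from compound 2 by hydrogen in place of benzyl on a nitrogen on an aromatic ring. Among the measured compounds shown here, no measured step bears on this change, since the step from compound 1 to compound 2 is unreadable and concerns a different position. What can be said rests on the limit of > 100000 nM in this assay, at which 2 of the 2 values shown sit: both measured compounds sit at the limit, so nothing suggests a readable step.

Compound 3 is therefore expected to show a step that the limit leaves unreadable from compound 2 to compound 3, that is, none beyond the scatter, with a high chance that only a limit is reported again. The estimate for compound 3 in this assay is 150000 nM, with a range from 40000 nM to 600000 nM.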

Compound 3, concentration for total growth inhibition: > 100000 nM
Compound 3 gave a limit, no number; the forecaster's own chance of this, stated with the estimate: 80%; the middle value is on the limit's open side.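

Compound 3 gives in this assay only a limit, > 100000 nM, so the steps that lead to it from compound 1 and from compound 2 cannot be read in size or direction. The compounds shown leave open whether any change on the shared core gives a readable growth inhibition in this assay, since all of them stand at one limit: the limit of > 100000 nM in this assay, at which 3 of the 3 values shown sit.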